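Swapping a Z-Drawn Double Bond for E

The compounds below may be only part of what the source reports. "The series", "measured", "known", "first", "only" and "open" are said of these compounds alone.

Measured compounds:
compound 1 `C=CCSSC=CC[S+]([O-])Cc1ccccc1`: 8900 nM
compound 2 `C=CCSS/C=C\C[S+]([O-])CCCOCc1ccc(OC)cc1`: 21000 nM

Both were tested in a functional assay on WHCO1 cells (Homo sapiens) for antiproliferative activity, read by MTT assay, with a stated time of 48 h; a higher number here means a weaker inhibitor, a lower number a stronger inhibitor. Of the two numbers, compound 2 has the higher one, so it is the weaker inhibitor of the pair; its nearest neighbour is compound 1, whose number is lower by an amount beyond the usual scatter. Compound 3 `C=CCSS/C=C/C[S+]([O-])CCCOCc1ccc(OC)cc1` has not yet been measured. It differs from compound 2 in a single drawn stereo element: the two compounds have the same atoms and bonds; at least one stereo element is drawn with a configuration in one of them and without one in the other: 1 of 2 stereo elements differ; a double bond is drawn Z in compound 2 and E in compound 3. Going by the values given here, no measured pair in this set shares that kind of change, so nothing here shows what such a swap does. The expectation is that the step from compound 2 to compound 3 will be small, with no clear direction, and will stay within the scatter. Compound 3 is therefore estimated to give 18000 nM in this assay, with a range from 7000 nM to 45000 nM. That estimate means an expected step of a 1.2-fold lower number from compound 2 to compound 3 (0.07 log units; within the scatter).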

Compound 3, half-maximal inhibitory concentration: 18000 nM
Compound 3: the middle estimate sits on the measured number at the digits printed, and the stated range covers the measured number.
By their numbers in this assay, from the lowest: compound 1; then compounds 3 and 2 (each within the scatter of the next).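

In this assay, drawing the double bond E rather than Z gives a 1.2-fold lower number from compound 2 to compound 3 (0.07 log units; within the scatter). Going by these compounds alone, this is the first direct look at this change, since compounds 2 and 3 share the same atoms and bonds, and it shows that with this chain attached, the two drawn geometries cannot be told apart in this read-out. The step still needs a caveat, as it rests on how the two structures are drawn, and the only recorded point about that drawing is this: the fact that one of compounds 2 and 3 is drawn with a defined configuration and the other without, at the place where they differ

A single pair cannot show whether the double bond would be equally undemanding with another chain in place of this ether chain. On these data alone, that question stays open for a longer chain, or for a chain ending in an amine or a carboxylic acid.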